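Nitro for cyano on the benzyl group: compound 4 expectation

This account rests on a few compounds, and the source may have more. Where it says the series, first, only, none or still open, it means among the compounds named here.

Measured compounds:
compound 1, `Cc1ccc(-c2nc3ccc(Br)cn3c2/C=N/OCc2cn(Cc3ccc([N+](=O)[O-])cc3)nn2)cc1`, 20 mg/kg
compound 2, `Cc1ccc(-c2nc3ccc(Br)cn3c2/C=N/OCc2cn(Cc3ccc(C#N)cc3)nn2)cc1`, 40 mg/kg
compound 3, `Cc1ccc(-c2nc3c(C)cccn3c2/C=N/OCc2cn(Cc3ccc(C#N)cc3)nn2)cc1`, 100 mg/kg

In a functional assay on the whole organism (strain NMRI) with Mus musculus as the target, with a stated time of 4 h (on this read-out higher numbers stand for an effect only at larger amounts of compound and lower numbers for an effect already at smaller amounts), compound 1 gives 20 mg/kg and compound 2 gives 40 mg/kg. The two share a core and differ only in the group on the benzyl ring: nitro in place of cyano on an aromatic carbon. The resulting step, a 2.0-fold lower number from compound 2 to compound 1 (0.30 log units; within the scatter), is within the scatter, so the two values are not distinguished here.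

Compound 3 carries a different core; how the core of compound 3 differs from that of compound 2 is not broken down here. Compound 3 gives 100 mg/kg, the highest of the three numbers, and its gap to compound 2 and to compound 1 lies beyond the scatter.

Compound 4, `Cc1ccc(-c2nc3c(C)cccn3c2/C=N/OCc2cn(Cc3ccc([N+](=O)[O-])cc3)nn2)cc1`, has the core of compound 3 and the same change as was made from compound 2 to compound 1: nitro in place of cyano on an aromatic carbon. For the measured compounds named here, only the one earlier instance of this change is available, and it gave a step within the scatter; the expected step is therefore a 2.0-fold lower number from compound 3 to compound 4 (0.30 log units; within the scatter), resting on a 2.0-fold lower number from compound 2 to compound 1 (0.30 log units; within the scatter). In this assay compound 4 is expected to give 50 mg/kg, with a range from 25 mg/kg to 100 mg/kg.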

Compound 4, minimum effective dose: 20 mg/kg
Estimate against measurement, compound 4: 2.5-fold (0.40 log units) above; measured number below the stated range.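

Nitro in place of cyano gives, in this assay, a 5.0-fold lower number from compound 3 to compound 4 (0.70 log units; beyond the scatter). Set beside the earlier step on the other core, the size of this change does not separate the two cores: the same change on two cores in this assay, a 2.0-fold lower number (0.30 log units; within the scatter) from compound 2 to compound 1 and a 5.0-fold lower number (0.70 log units; beyond the scatter) from compound 3 to compound 4, 2.5-fold (0.40 log units) apart, within the scatter of two such steps

This supports treating the swap as carrying over between these two cores, and no further; two pairs do not show that one core gives a larger step than the other, and they give no rule for any third core.

The compounds shown hold only 4-cyanobenzyl and 4-nitrobenzyl at the varied group, so it stays open how a benzyl group carrying an amine or a carboxylic acid, or a longer chain in place of the benzyl group, would read in this assay. Also open, going by these compounds, is whether the swap keeps a comparable size on cores other than these two.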